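Dropping the Chloro Between Two Ring Nitrogens

This account rests on a few compounds, and the source may have more. Where it says the series, first, only, none or still open, it means among the compounds named here.

Compound 2 `ClCc1cccc(Cn2cnc3nc(Cl)nc(Cl)c32)c1` and compound 1 `Nc1nc(Cl)c2ncn(Cc3ccccc3CCl)c2n1` were tested in a functional assay on SK-MEL-28 cells (Homo sapiens) for cytotoxicity, read by sulforhodamine B assay, with a stated time of 48 h; on this read-out higher numbers stand for weaker inhibition of growth and lower numbers for stronger inhibition of growth. Compound 2 gives 170 nM and compound 1 gives 4790 nM, so compound 2 stands lowest of the two numbers, beyond the scatter of compound 1. Compound 3 `ClCc1cccc(Cn2cnc3ncnc(Cl)c32)c1` has not yet been measured. It differs from compound 2 as follows: hydrogen in place of chloro on an aromatic carbon. Among the compounds with values here, with no measured step of this kind to draw on, a moderate loss of growth inhibition is expected, as a 2.9-fold higher number from compound 2 to compound 3 (0.47 log units; beyond the scatter). Compound 3 is therefore estimated at 500 nM, within a range from 150 nM to 2000 nM.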

Compound 3, concentration for 50% growth inhibition: 1810 nM
The estimate for compound 3 lay 3.6-fold (0.56 log units) below the measured number; measured number inside the range.
By their numbers in this assay, from the lowest: compound 2; then compound 3; then compound 1.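

In this assay, taking the chloro off the aromatic carbon between two ring nitrogen atoms gives an 11-fold higher number from compound 2 to compound 3 (1.03 log units; beyond the scatter), a large loss of growth inhibition. Within the data shown here, this is the first step that changes one place only, and it shows that growth inhibition depends strongly on what sits at this position. Nothing measured here explains the size of this step. Still open, on these data alone, is whether an amine, a methoxy group or a fluoro at this position would keep the number near that of compound 2 or leave it near that of compound 3.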